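The source may report more compounds than this note shows. Statements on the series, on what has been measured and on what is new or still open speak of the compounds shown alone.

Measured in an ADME assay on L6 cells (Rattus norvegicus) for cytotoxicity, read by fluorescence, with a stated time of 72 h; on this read-out lower numbers stand for stronger inhibition and higher numbers for weaker inhibition:
- compound 1 `CN1CCN(C23CC(NC(=O)CN4CCCC4)C(C(c4ccccc4)C2)C(c2ccccc2)C3)CC1`: 27800 nM
- compound 2 `CCN(CC)CC(=O)NC1CC2(N3CCN(C)CC3)CC(c3ccccc3)C1C(c1ccccc1)C2`: 26400 nM
- compound 3 `CN1CCN(C23CC(NC(=O)CN4CCCCC4)C(C(c4ccccc4)C2)C(c2ccccc2)C3)CC1`: 22100 nM

Compound 3 does not separate from compound 2: a 1.2-fold lower number from compound 2 to compound 3 (0.08 log units; within the scatter). The next structure is compound 4 `CN1CCN(C23CC(NCCCN4CCCC4)C(C(c4ccccc4)C2)C(c2ccccc2)C3)CC1`, and the change is 3-(pyrrolidin-1-yl)propyl in place of ((piperidin-1-yl)methyl)carbonyl on an amine nitrogen. Only the end ring of this change has a measured counterpart, seen the other way round in a 1.3-fold lower number from compound 1 to compound 3 (0.10 log units; within the scatter). The third exchange among these end groups, a 1.1-fold lower number from compound 1 to compound 2 (0.02 log units; within the scatter), was just as small. Among the compounds with values here, all three measured compounds keep the carbonyl and the same chain, so no measured step shows what happens when the carbonyl leaves and the chain changes. These small steps therefore cannot be carried over to compound 4 with confidence. The change is much larger than any exchange measured so far, so a real step is expected, though its direction is only a tentative call. In this assay the expected outcome is a 2.0-fold lower number from compound 3 to compound 4 (0.30 log units; within the scatter). The estimate for compound 4 is 11000 nM, with an expected range of 3500 nM to 30000 nM.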

Compound 4, half-maximal inhibitory concentration: 22600 nM
Compound 4: the middle estimate sits 2.1-fold (0.31 log units) below what was measured; measured number inside the range.
By their numbers in this assay, from the lowest: compounds 3, 4, 2 and 1 (each within the scatter of the next).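

In this assay, within the data shown here, the first exchange that removes the carbonyl from this amine nitrogen, 3-(pyrrolidin-1-yl)propyl in place of ((piperidin-1-yl)methyl)carbonyl, gives a 1.0-fold higher number from compound 3 to compound 4 (0.01 log units; within the scatter) and no real step. The other two exchanges agree: a 1.2-fold lower number from compound 2 to compound 4 (0.07 log units; within the scatter) is within the scatter, and a 1.2-fold lower number from compound 1 to compound 4 (0.09 log units; within the scatter) keeps the pyrrolidin-1-yl end ring, so it isolates the loss of the carbonyl and the change of chain. Across these four compounds, neither the end group nor the carbonyl-bearing chain separates the numbers, and no supporting measurement explains this flat result.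

Still open, going by these compounds, is whether any group on this nitrogen can separate from these numbers, such as a carboxylic acid, a morpholine end ring or a much longer chain. The piperidin-1-yl end ring on the propyl chain also remains untested among the compounds shown.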